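Dropping One Chlorine from Compound 2

The compounds below may be only part of what the source reports. "The series", "measured", "known", "first", "only" and "open" are said of these compounds alone.

In a functional assay on IGROV-1 cells (Homo sapiens) for cytotoxicity, read by sulforhodamine B assay, with a stated time of 48 h (on this read-out higher numbers stand for weaker inhibition of growth and lower numbers for stronger inhibition of growth), compound 2 `ClCc1ccccc1Cn1cnc2nc(Cl)nc(Cl)c21` gives 2880 nM. Compound 1 `ClCc1cccc(Cn2cnc3c(Cl)nc(Cl)nc32)c1` gives 2290 nM, a number within the scatter of that of compound 2, so the two cannot be told apart. Compound 3 `ClCc1ccc(Cn2cnc3c(Cl)nc(Cl)nc32)cc1` gives 15100 nM, a higher number than compound 2, beyond the scatter. Compound 4 `ClCc1ccccc1Cn1cnc2ncnc(Cl)c21` has not yet been measured; it differs from compound 2 in one place: hydrogen in place of chloro on an aromatic carbon. For the measured compounds named here, no measured pair shows what this exchange does, so the expectation rests on the structural change alone. All three measured compounds keep both chlorines on the shared core; the loss of one is expected to bring a modest step of a 1.6-fold higher number from compound 2 to compound 4 (0.19 log units; within the scatter) toward a higher number. Compound 4 is expected to give about 4500 nM, within 1500 nM to 14000 nM.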

Compound 4, concentration for 50% growth inhibition: 4260 nM
Estimate against measurement, compound 4: 1.1-fold (0.02 log units) above, and the stated range covers the measured number.
By their numbers in this assay, from the lowest: compounds 1, 2 and 4 (each within the scatter of the next); then compound 3.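

In this assay, hydrogen in place of chloro on the aromatic carbon between two ring nitrogen atoms gives a 1.5-fold higher number from compound 2 to compound 4 (0.17 log units; within the scatter) and so the two compounds cannot be told apart. For the compounds shown here, this pair is the first direct reading of this exchange, and it shows that this chloro group can be lost without a change that rises above the scatter. Nothing measured here explains this result. From the compounds shown here alone, whether an amine or a methoxy group on this carbon would behave like hydrogen remains open, as does the effect of replacing the other chloro group on the shared core.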